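The compounds below may be only part of what the source reports. "The series", "measured", "known", "first", "only" and "open" are said of these compounds alone.

Compound 1 `O=C1NC(=O)C(Cc2ccc(Oc3ncc(Cl)cc3Cl)cc2)S1` gives 90 nM in a functional assay for agonist activity at Free fatty acid receptor 1 (Homo sapiens), read by FLIPR, in the presence of a further agent that is not named here; on this read-out higher numbers stand for an effect only at larger amounts of compound and lower numbers for an effect already at smaller amounts.
Compound 2 `Cc1ccc(C)c(Oc2ccc(CC3SC(=O)NC3=O)cc2)c1` gives 238 nM in this assay.
Compound 3 `O=C1NC(=O)C(Cc2ccc(Oc3ccc(Cl)cc3Cl)cc2C(F)(F)F)S1` gives 88 nM in this assay.

Among these three numbers compound 1 holds the second highest. Its nearest neighbour is compound 3, whose number lies so close that the two cannot be told apart within the scatter. The furthest is compound 2, whose number lies beyond the scatter above that of compound 1. The gap between compound 1 and compound 2 thus stands as the one difference in this set that counts.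

The next compound, compound 4 `O=C1NC(=O)C(Cc2ccc(Oc3ccc(Cl)cn3)cc2)S1`, has not yet been measured in this assay. It is reached from compound 1 by one change: hydrogen in place of chloro on an aromatic carbon. Among the measured compounds shown here, no measured pair in this set differs in one place, so there is no direct precedent for what a change of this kind does here. A step beyond the scatter, towards a higher number, is nonetheless what is expected, a 2.2-fold higher number from compound 1 to compound 4 (0.35 log units; beyond the scatter). For compound 4 the expected value in this assay is 200 nM, with a range from 70 nM to 600 nM.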

Compound 4, half-maximal effective concentration: 1870 nM
Compound 4: the middle estimate sits 9.4-fold (0.97 log units) below what was measured; measured number above the stated range.
By their numbers in this assay, from the lowest: compounds 3 and 1 (each within the scatter of the next); then compound 2; then compound 4.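

In this assay, the chloro on the six-membered aromatic ring with 1 nitrogen, ortho to a large group and meta to a chloro group, proves to weigh heavily: hydrogen in its place brings a 21-fold higher number from compound 1 to compound 4 (1.32 log units; beyond the scatter), a large step. Among the compounds shown here, this is the first change in a single place in the set, and it shows that the other chloro, which compound 4 keeps, does not alone hold the number near that of compound 1. Nothing available accounts for the size of this step.

As far as these compounds go, it remains open whether a fluoro, a methoxy or a nitrile group at this position would keep the number of compound 1 or follow that of compound 4. From the compounds shown here alone, it is also open whether the same change would weigh as much on a ring without the nitrogen.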